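This account rests on a few compounds, and the source may have more. Where it says the series, first, only, none or still open, it means among the compounds named here.

Measured compounds in a functional assay on MCF7 cells (Homo sapiens) for antiproliferative activity, read by MTT assay, with a stated time of 72 h; on this read-out higher numbers stand for weaker inhibition and lower numbers for stronger inhibition:
compound 1, `COc1cc(-n2cnc3ccc(-c4cccc(C)c4C)cc32)cc(OC)c1OC`: 2150 nM
compound 2, `COc1cc(-n2cnc3ccc(-c4ccccc4)cc32)cc(OC)c1OC`: 2290 nM
compound 3, `COc1cc(-n2cnc3ccc(-c4cccc(O)c4)cc32)cc(OC)c1OC`: 350 nM

Compound 3 gives the lowest of the three numbers in this assay; its step from compound 1 is a 6.1-fold lower number from compound 1 to compound 3 (0.79 log units; beyond the scatter) and from compound 2 is a 6.5-fold lower number from compound 2 to compound 3 (0.82 log units; beyond the scatter), both beyond the scatter. Compound 1 and compound 2 sit within the scatter of each other, a 1.1-fold higher number from compound 1 to compound 2 (0.03 log units; within the scatter).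

Compound 4, `COc1cc(-n2cnc3ccc(-c4ccc(C(C)=O)cc4)cc32)cc(OC)c1OC`, is not yet measured. The change from compound 3 is 4-acetylphenyl in place of 3-hydroxyphenyl on an aromatic carbon. The hydrogen-bond donor of compound 3 leaves; one acceptor remains. The step that bears most directly on this is a 6.5-fold lower number from compound 2 to compound 3 (0.82 log units; beyond the scatter), where hydroxy in place of hydrogen brought the whole gain of compound 3 over compound 2; a 1.1-fold higher number from compound 1 to compound 2 (0.03 log units; within the scatter) shows that changing the aryl otherwise moved the number little. With the hydroxy gone, the expected step is a 4.6-fold higher number from compound 3 to compound 4 (0.66 log units; beyond the scatter), upward, back toward the numbers of compound 1 and compound 2. In this assay compound 4 is expected at 1600 nM, with a range of 500 nM to 4500 nM.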

Compound 4, half-maximal inhibitory concentration: 1540 nM
Compound 4: the middle estimate sits 1.0-fold (0.02 log units) above what was measured; measured number inside the range.
By their numbers in this assay, from the lowest: compound 3; then compounds 4, 1 and 2 (each within the scatter of the next).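

In this assay, the 3-hydroxyphenyl and 4-acetylphenyl groups carry the same hydrogen-bond acceptor count, yet a 4.4-fold higher number from compound 3 to compound 4 (0.64 log units; beyond the scatter), so an acceptor on this aryl group does not by itself keep the low number of compound 3. The acetyl also gives no separation from the plain phenyl, with a 1.5-fold lower number from compound 2 to compound 4 (0.17 log units; within the scatter), or from 2,3-dimethylphenyl, with a 1.4-fold lower number from compound 1 to compound 4 (0.14 log units; within the scatter), leaving compound 3 alone apart from the other three compounds. No measurement shown gives a reason for this pattern.

The step from compound 3 to compound 4 changes both the group and its place on the ring, so the donor and the placement cannot yet be separated. Hydroxy in the place of the acetyl of compound 4 would test placement, while an amine or a carboxylic acid in the place of the hydroxy of compound 3 would test how specific the hydroxy is.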